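The source may hold more compounds than are shown below. What is called first, only, known or untested is meant among the compounds shown, and "the series" means these compounds.

In an ADME assay on PA-1 cells (Homo sapiens) for cytotoxicity, read by MTT assay, with a stated time of 72 h (on this read-out higher numbers stand for weaker inhibition and lower numbers for stronger inhibition), compound 1 `COc1ccc(C2=C(c3cc(OC)c(OC)c(OC)c3)C(=O)CC2O[SiH2]C(C)(C)C)cc1` gives > 100 ug/mL, and this value is a limit of the assay. Compound 2 `COc1ccc(C2=C(c3cc(OC)c(OC)c(OC)c3)C(=O)C(O)C2)cc1` gives < 1 ug/mL, which is also a limit. Compound 3 `COc1ccc(OC)c(C2=C(c3cc(OC)c(OC)c(OC)c3)C(=O)CC2O[SiH2]C(C)(C)C)c1` keeps the core of compound 1 and differs from it in one place, with 2,5-dimethoxyphenyl in place of 4-methoxyphenyl on a double-bonded ring carbon. For the measured compounds named here, no measured step bears on this change, so nothing beyond the scatter is expected in this assay, and the estimated step is a number no higher from compound 1 to compound 3 (the limit leaves the size open). For compound 3 the expected value is 100 ug/mL, within an estimated range from 40 ug/mL to 250 ug/mL.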

Compound 3, half-maximal inhibitory concentration: 17 ug/mL
Beside the measured number, compound 3's estimate is 5.9-fold (0.77 log units) above it; measured number outside the range, below it.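

In this assay, 2,5-dimethoxyphenyl in place of 4-methoxyphenyl on a double-bonded ring carbon gives an at least 5.8-fold lower number from compound 1 to compound 3 (0.76 log units; beyond the scatter). For the compounds shown here, this is the first sign that the number responds to a change at this position, with the rest of the core of compound 1 left as it is. Only one end of the step is a firm number, so its full size stays open: the limit of > 100 ug/mL in this assay, at which 1 of the 3 values shown sits.

The compounds shown leave open which of the two methoxy groups of 2,5-dimethoxyphenyl accounts for the step. They also leave open how an aminophenyl or a hydroxyphenyl at this position would read.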